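Working notes on a prostaglandin D2 receptor 2 antagonist series

The source may report more compounds than this note shows. Statements on the series, on what has been measured and on what is new or still open speak of the compounds shown alone.

Measured compounds:
- compound 1, `Cc1nc(-c2ccc(Cl)cc2)c(CC(=O)O)s1`: in an in vitro functional assay on HEK285-7 cells for antagonist activity at prostaglandin D2 receptor 2 (Homo sapiens), read by BRET and beta-arrestin recruitment (on this read-out lower numbers stand for stronger inhibition and higher numbers for weaker inhibition), compound 1 gives 41000 nM
- compound 2, `COc1cc(-c2nc(C(c3ccc(F)cc3)c3ccc(F)cc3)sc2CC(=O)O)ccn1`: in this assay compound 2 gives 380 nM
- compound 3, `O=C(O)Cc1sc(C(c2ccccc2)c2ccc(Cl)cc2)nc1-c1ccc(F)cc1`: in this assay compound 3 gives 79 nM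

Compound 2 stands second highest of the three numbers. Its nearest neighbour is compound 3, whose number is lower by a gap beyond the scatter; compound 1 lies far higher, also beyond the scatter. Compounds 2 and 3 differ in more than one place, so their two values are only compared as they stand, without a single change to pin the gap on.

Compound 4, `O=C(O)Cc1sc(C(c2ccc(F)cc2)c2ccc(F)cc2)nc1-c1ccnc(O)c1`, is the next member to be measured. Relative to compound 2 the change is hydrogen in place of methyl on an oxygen on an aromatic ring. No comparable change has been measured in this set, so the expectation rests on compound 2 alone. A modest weakening is expected, a step of a 1.8-fold higher number from compound 2 to compound 4 (0.27 log units; within the scatter), small but possibly just beyond the scatter. The estimate for compound 4 is 700 nM, with a range from 200 nM to 2500 nM.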

Compound 4, half-maximal inhibitory concentration: 890 nM
The estimate for compound 4 lay 1.3-fold (0.10 log units) below the measured number; the measured number falls inside the stated range.
By their numbers in this assay, from the lowest: compound 3; then compound 2; then compound 4; then compound 1.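

On the 2-methoxypyridin-4-yl group, going from methoxy to hydroxy gives a 2.3-fold higher number from compound 2 to compound 4 (0.37 log units; beyond the scatter) in this assay, the only change in a single place among the compounds shown. The methyl on that oxygen therefore has a measurable effect on this read-out, although the step is modest and compound 4 keeps 890 nM with hydrogen in its place. The data shown offer no measurement that would explain this step.

From the compounds shown here alone, it remains open whether the effect follows the methyl specifically or would also appear with another group on the same ring carbon, such as an ethoxy or an amine. Among these compounds, whether the same change gives a step of similar size with other substituents on the shared core also remains open, as no second matched pair is available.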